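This account rests on a few compounds, and the source may have more. Where it says the series, first, only, none or still open, it means among the compounds named here.

Compound 3, with structure `COC(=O)c1ccc(NCc2cncn2Cc2ccccc2F)cc1-c1ccccc1`, is the starting point of this step, yet for it the result in a toxicity assay on NIH3T3 cells (Mus musculus) for cytotoxicity, read by resazurin assay (on this read-out higher numbers stand for an effect only at larger amounts of compound and lower numbers for an effect already at smaller amounts), is recorded as "not determined" (no result reported), so no number of its own can be placed. Compound 1, with structure `COC(=O)c1ccc(NCc2cncn2Cc2ccccc2Cl)cc1-c1ccccc1`, gives 10000 nM in this assay. Compound 2, with structure `COC(=O)c1ccc(NCc2cncn2Cc2ccc(-c3ccccc3)cc2)cc1`, gives only a limit of the assay, > 10000 nM, which is the boundary described by the limit of > 10000 nM in this assay, at which 1 of the 3 values shown sits. Going by the values given here, the close relatives of compound 3 thus sit at the upper edge of what this assay resolves, and nothing among the measured pairs differs in a single place, so no measured step is available.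

Compound 4, with structure `COC(=O)c1ccc(NCc2cncn2Cc2ccccc2[N+](=O)[O-])cc1-c1ccccc1`, is not yet measured. It differs from compound 3 by nitro in place of fluoro on an aromatic carbon. Among the compounds with values here, with no measured step of this kind to lean on, no shift beyond the usual scatter is expected in either direction; the measured relatives suggest that compound 4 would show an effect only at large amounts, if at all. For compound 4 the value in this assay is therefore estimated at 10000 nM, expected to fall between 5000 nM and 20000 nM, with a real chance that the assay again reports only a limit.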

Compound 4, half-maximal effective concentration: 10000 nM
Beside the measured number, compound 4's estimate shows no gap at the digits printed; measured number inside the range.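

Going by these compounds alone, replacing chloro with nitro at this position gives the first measured comparison of two compounds that differ in one place in this assay, and it reads no change at the digits printed from compound 1 to compound 4 (within the scatter). Within the data shown here, at this spot on the ring, ortho to a large group, the two groups thus give the same reading on the shared core, something the earlier compounds could not show, as none of their pairs differed in a single place. Both readings also lie close to the top of what this test can resolve, so this comparison says little about any stronger effect, and one compound in the set already reaches the edge: the limit of > 10000 nM in this assay, at which 1 of the 4 values shown sits.

Going by these compounds, the step from fluoro to nitro itself cannot be read, as compound 3 has no result, so whether the fluoro compound behaves like compound 1 and compound 4 remains unknown. On these data alone, it also remains open whether an amine or a carboxylic acid on this aromatic carbon would bring the effect down to smaller amounts of compound, or whether the reading would stay where chloro and nitro leave it.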